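(4-Fluorophenyl)sulfonyl to (4-hydroxyphenyl)sulfonyl: working notes

The source may hold more compounds than are shown below. What is called first, only, known or untested is meant among the compounds shown, and "the series" means these compounds.

In a functional assay on MCF7 cells (Homo sapiens) for inhibition, read by trypan blue exclusion, with a stated time of 72 h (on this read-out lower numbers stand for stronger inhibition of growth and higher numbers for weaker inhibition of growth), compound 2 (`Cn1c(=O)c(S(=O)(=O)c2ccc(F)cc2)cc2cnc(Nc3ccc4[nH]ccc4c3)nc21`) gives 250 nM and compound 1 (`Cn1c(=O)c(S(=O)(=O)c2ccc(OC(=O)CCCCC3SCC4NC(=O)NC43)cc2)cc2cnc(Nc3ccc4[nH]ccc4c3)nc21`) gives 500 nM so the two sit within the scatter of each other, and compound 2 has no separate standing on these numbers.

The next compound is compound 3 (`Cn1c(=O)c(S(=O)(=O)c2ccc(O)cc2)cc2cnc(Nc3ccc4[nH]ccc4c3)nc21`). It keeps the core of compound 2 and differs in one place: hydroxy in place of fluoro on an aromatic carbon with hydroxy in place of fluoro on an aromatic carbon, para to a large group. In other words, 4-fluorophenyl becomes 4-hydroxyphenyl.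

Among the measured compounds shown here, the two measured compounds do not differ in one place, so no measured step speaks to this exchange. What data exist give only a starting point, compound 2 at 250 nM as the anchor for the expectation.

Estimated for this exchange is a 1.2-fold higher number from compound 2 to compound 3 (0.08 log units; within the scatter) which means that no change beyond the scatter is expected in this assay and no firm direction is assumed. For compound 3 the estimate is 300 nM with an expected range from 100 nM to 900 nM around it.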

Compound 3, concentration for 50% growth inhibition: 500 nM
Beside the measured number, compound 3's estimate is 1.7-fold (0.22 log units) below it, and the stated range covers the measured number.
By their numbers in this assay, from the lowest: compounds 2, 1 and 3 (each within the scatter of the next).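

Read in one place for the first time, the exchange of fluoro for hydroxy on an aromatic carbon para to a large group gives, in this assay, a 2.0-fold higher number from compound 2 to compound 3 (0.30 log units; within the scatter). At this position, therefore, a hydrogen-bond donor and acceptor can enter in place of fluoro without moving the growth-inhibition number beyond the scatter, which the earlier pair, differing by a long ester-linked chain and more, could not show as a single exchange. The data offer nothing that explains this flat reading, and the result stands as an observation on this one pair.

Still open, from the compounds shown here alone, is whether an amine, a carboxylic acid or a methoxy group on the same aromatic carbon would also stay within the scatter of compound 2, or whether any of them would move the number clearly in either direction. Open too, going by these compounds, is whether the same indifference to the fluoro-to-hydroxy exchange would hold with a different anilino group on the shared core, since here it rests on a single matched pair in one cell line.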